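Amide-nitrogen swap on a shared pyrazole-carboxamide core

The compounds below may be only part of what the source reports. "The series", "measured", "known", "first", "only" and "open" are said of these compounds alone.

Compound 1, `Cc1ccc(-c2cc(C(=O)Nc3ccncc3Br)nn2-c2ccc3ccccc3n2)cc1`, gives 15500 nM in a functional assay on HCT-116 cells (Homo sapiens) for cytotoxicity, read by sulforhodamine B assay, with a stated time of 72 h; on this read-out higher numbers stand for weaker inhibition and lower numbers for stronger inhibition.
Compound 2, `Cc1ccc(-c2cc(C(=O)Nc3ccc(Cl)nc3Cl)nn2-c2ccc3ccccc3n2)cc1`, gives 7900 nM in this assay.
Compound 3, `Cc1ccc(-c2cc(C(=O)NCc3cccnc3)nn2-c2ccc3ccccc3n2)cc1`, gives 11200 nM in this assay.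

Compound 1 has the highest number of the three, yet every step among them stays within the scatter: a 2.0-fold lower number from compound 1 to compound 2 (0.29 log units; within the scatter), a 1.4-fold lower number from compound 1 to compound 3 (0.14 log units; within the scatter), and a 1.4-fold higher number from compound 2 to compound 3 (0.15 log units; within the scatter). Compound 4, `COc1ncccc1NC(=O)c1cc(-c2ccc(C)cc2)n(-c2ccc3ccccc3n2)n1`, has not yet been measured. It differs from compound 1 in one place: 2-methoxypyridin-3-yl in place of 3-bromopyridin-4-yl on an amide-type nitrogen. All three measured steps are exchanges of the group on the amide-type nitrogen, and none moved the number beyond the scatter, so the expectation for this assay is a step no larger than that. Compound 4 is therefore expected at 12000 nM, within 5000 nM to 30000 nM, which means an expected 1.3-fold lower number from compound 1 to compound 4 (0.11 log units; within the scatter).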

Compound 4, half-maximal inhibitory concentration: 15700 nM
The estimate for compound 4 lay 1.3-fold (0.12 log units) below the measured number; measured number inside the range.
By their numbers in this assay, from the lowest: compounds 2, 3, 1 and 4 (each within the scatter of the next).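

The 2-methoxypyridin-3-yl group on the amide-type nitrogen in this assay gives a 1.0-fold higher number from compound 1 to compound 4 (0.01 log units; within the scatter) and a 1.4-fold higher number from compound 3 to compound 4 (0.15 log units; within the scatter) and a 2.0-fold higher number from compound 2 to compound 4 (0.30 log units; within the scatter) as its steps. A methoxy-bearing ring therefore joins the bromo, dichloro and (pyridin-3-yl)methyl groups, and no exchange among these four compounds at this position moves the number beyond the scatter. Nothing available explains this result.

On these data alone, whether an amine or a carboxylic acid on the pyridine ring would move the number beyond the scatter stays open. So does whether a longer alkyl chain on the amide-type nitrogen would do so.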